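The source may hold more compounds than are shown below. What is called first, only, known or untested is meant among the compounds shown, and "the series" means these compounds.

In an assay on cells with melanin-concentrating hormone receptor 1 (Homo sapiens) as the target, read by radioligand binding (a lower number here means a stronger inhibitor, a higher number a weaker inhibitor), compound 2 `Nc1ccc2cccc(OCCC(F)(F)F)c2n1` gives 722 nM, and compound 3 `CC1CC1COc1cccc2ccc(N)nc12` gives 1640 nM. The step of a 2.3-fold higher number from compound 2 to compound 3 (0.36 log units; beyond the scatter) leaves compound 3 with the higher of the two measured numbers. Compound 1 `CCOCCOc1cccc2ccc(N)nc12` gives > 2000 nM, which is a limit of the assay rather than a number (the limit of > 2000 nM in this assay, at which 1 of the 3 values shown sits). From compound 1 the steps of an at least 2.7-fold lower number from compound 1 to compound 2 (0.44 log units; beyond the scatter) and an at least 1.2-fold lower number from compound 1 to compound 3 (0.08 log units; that floor lies within the scatter) both run downward, the second only as far as a floor within the scatter. Compound 4 `COC(C)(C)CCOc1cccc2ccc(N)nc12` differs from compound 3 by 2-methoxy-2-methylpropyl in place of 2-methylcyclopropyl on a saturated chain carbon bound to an oxygen on an aromatic ring. The chain of compound 4 carries an ether oxygen, as does the chain of compound 1, whose step an at least 1.2-fold lower number from compound 1 to compound 3 (0.08 log units; that floor lies within the scatter) started from a limit. Compound 4 is therefore expected to climb in this assay by a 1.5-fold higher number from compound 3 to compound 4 (0.18 log units; within the scatter). Compound 4 is estimated at 2500 nM, between 1000 nM and 6000 nM.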

Compound 4, half-maximal inhibitory concentration: 132 nM
Estimate against measurement, compound 4: 19-fold (1.28 log units) above; measured number below the stated range.
By their numbers in this assay, from the lowest: compound 4; then compound 2; then compound 3. At a limit, above all of these: compound 1.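

In this assay the change to 2-methoxy-2-methylpropyl gives a 12-fold lower number from compound 3 to compound 4 (1.09 log units; beyond the scatter) and also a 5.5-fold lower number from compound 2 to compound 4 (0.74 log units; beyond the scatter), so this position can hold a bigger chain and reach a lower number than any earlier compound. An ether oxygen in the chain is thus no bar to a low number, though compound 1 also carries one: the step is an at least 15-fold lower number from compound 1 to compound 4 (1.18 log units; beyond the scatter) in this comparison. That step is only a floor, since compound 1 stands at a limit: the limit of > 2000 nM in this assay, at which 1 of the 4 values shown sits.

On these data alone, whether the methoxy group or the branched carbon matters more stays open, as does how an amine or a carboxylic acid on this chain would compare.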